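The source may report more compounds than this note shows. Statements on the series, on what has been measured and on what is new or still open speak of the compounds shown alone.

Compound 1 `CCOc1cc(C)c(C(=O)N=C(N)N)cc1S(C)(=O)=O`: 19 nM in a functional assay for inhibition of sodium/hydrogen exchanger (Oryctolagus cuniculus); a higher number here means a weaker inhibitor, a lower number a stronger inhibitor
Compound 2 `Cc1cc(N2CCCC(O)C2)c(S(C)(=O)=O)cc1C(=O)N=C(N)N`: 30 nM
Compound 3 `Cc1ccc(S(C)(=O)=O)cc1C(=O)N=C(N)N`: 150 nM

Compound 3 gives the highest number of the three in this assay, with compound 2 nearest and compound 1 furthest from it. Compound 4 `Cc1cc(-n2ccc(=O)cc2)c(S(C)(=O)=O)cc1C(=O)N=C(N)N` carries a group of 7 heavy atoms (5 carbon, 1 nitrogen, 1 oxygen; one six-membered aromatic ring with 1 hetero atom) in place of a hydrogen atom, on an aromatic carbon, on the aromatic carbon ortho to the methylsulfonyl group. Within the data shown here, two measured steps bear on this change: a 7.9-fold higher number from compound 1 to compound 3 (0.90 log units; beyond the scatter) and a 5.0-fold higher number from compound 2 to compound 3 (0.70 log units; beyond the scatter), both showing that a group on that carbon, rather than hydrogen, goes with a lower number beyond the scatter. Restoring a group there is therefore expected to lower the number for compound 4, by a step estimated at a 4.3-fold lower number from compound 3 to compound 4 (0.63 log units; beyond the scatter). The entering ring differs from both ethoxy and 3-hydroxypiperidin-1-yl, so its size is uncertain. Compound 4 is expected to give 35 nM in this assay, range 12 nM to 110 nM.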

Compound 4, half-maximal inhibitory concentration: 75 nM
Estimate against measurement, compound 4: 2.1-fold (0.33 log units) below; the range from low to high includes it.
By their numbers in this assay, from the lowest: compounds 1 and 2 (each within the scatter of the next); then compounds 4 and 3 (each within the scatter of the next).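

In this assay, a group on the aromatic carbon ortho to a methylsulfonyl group does not always separate from hydrogen: the six-membered aromatic ring with 1 hetero atom stays within the scatter (a 2.0-fold lower number from compound 3 to compound 4 (0.30 log units; within the scatter)). The same ring gives higher numbers than the two earlier groups, 3-hydroxypiperidin-1-yl (a 2.5-fold higher number from compound 2 to compound 4 (0.40 log units; beyond the scatter)) and ethoxy (a 3.9-fold higher number from compound 1 to compound 4 (0.60 log units; beyond the scatter)), so the identity of the group matters at this position, not merely its presence. No available evidence explains this difference.

Still open, as far as these compounds go, is how a primary amine, a carboxylic acid or a longer alkoxy chain would read on this carbon.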